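The compounds below may be only part of what the source reports. "The series", "measured", "known", "first", "only" and "open" are said of these compounds alone.

Measured so far in a functional assay on MV4-11 cells (Homo sapiens) for antiproliferative activity, read by CCK-8 assay, with a stated time of 72 h; a lower number here means a stronger inhibitor, a higher number a weaker inhibitor:
- compound 1 (`CC(C)Oc1ccc(C(C)(C)O)cc1-c1cn(C)c(=O)c2[nH]c(C(=O)NCCCCCCC(=O)NO)cc12`): 160 nM
- compound 2 (`Cn1cc(-c2cc(C(C)(C)O)ccc2Oc2ccc(F)cc2F)c2cc(C(=O)NCc3ccc(C(=O)NO)cc3)[nH]c2c1=O`): 190 nM

Compound 2 stands within the scatter of compound 1, so these two values give no ranking. Compound 3 (`Cn1cc(-c2cc(C(C)(C)O)ccc2Oc2ccc(F)cc2F)c2cc(C(=O)NCCCCCCC(=O)NO)[nH]c2c1=O`) has not yet been measured. Its structural change from compound 2 is 5-(hydroxycarbamoyl)pentyl in place of 4-(hydroxycarbamoyl)phenyl on a saturated chain carbon bound to an amide-type nitrogen. Within the data shown here, no measured step isolates this change, so the expectation rests on thin evidence. Compound 1 also carries 6-(hydroxycarbamoyl)hexyl and gives 160 nM in this assay, which points to no step beyond the scatter in this assay. The expected change is a 1.3-fold lower number from compound 2 to compound 3 (0.10 log units; within the scatter) and no clear direction is expected. For compound 3 the estimated value is 150 nM with an expected range from 50 nM to 450 nM in these cells.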

Compound 3, half-maximal inhibitory concentration: 250 nM
Beside the measured number, compound 3's estimate is 1.7-fold (0.22 log units) below it; the measured number falls inside the stated range.
By their numbers in this assay, from the lowest: compounds 1, 2 and 3 (each within the scatter of the next).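

In this assay, 5-(hydroxycarbamoyl)pentyl in place of 4-(hydroxycarbamoyl)phenyl on a saturated chain carbon bound to an amide-type nitrogen now has a direct reading: a 1.3-fold higher number from compound 2 to compound 3 (0.12 log units; within the scatter) and so, with 2,4-difluorophenyl on the oxygen, the open chain and the ring-bearing linker cannot be told apart in these cells. Among these compounds, the group on the oxygen can also be read for the first time: with 6-(hydroxycarbamoyl)hexyl held fixed, 2,4-difluorophenyl in place of isopropyl gives a 1.6-fold higher number from compound 1 to compound 3 (0.19 log units; within the scatter) and so shows no separable effect either. Nothing measured here offers an explanation for these results.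

On these data alone, whether a longer chain, or a carboxylic acid in place of the hydroxycarbamoyl group, would give a step beyond the scatter stays open. As far as these compounds go, it is also open whether a methyl group on the oxygen would move the number.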